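The compounds below may be only part of what the source reports. "The series", "measured", "known", "first", "only" and "open" are said of these compounds alone.

Measured so far:
compound 1 `O=C(CN1CCN(c2nnc(Cc3ccncc3)c3ccccc23)CC1)Nc1ccc(F)c(F)c1`: 2320 nM
compound 2 `Cc1ccc(NC(=O)CN2CCN(c3nnc(Cc4ccccc4)c4ccccc34)CC2)c(C)c1`: "not active" (no number reported)
compound 3 `Cc1ccc(NC(=O)CN2CCN(c3nnc(Cc4ccncc4)c4ccccc34)CC2)c(C)c1`: 1930 nM

In a functional assay on HT-29 cells (Homo sapiens) for cytotoxicity, read by MTT assay, with a stated time of 72 h (on this read-out lower numbers stand for stronger inhibition and higher numbers for weaker inhibition), compound 2 is reported as "not active" (no number reported), so no single number stands for it. The unmeasured compound 4 `O=C(CN1CCN(c2nnc(Cc3ccccc3)c3ccccc23)CC1)Nc1cc(C(F)(F)F)ccc1Cl` differs from compound 2 in one place: 2-chloro-5-(trifluoromethyl)phenyl in place of 2,4-dimethylphenyl on an amide-type nitrogen. Going by the values given here, the only measured step at the amide-type nitrogen is a 1.2-fold lower number from compound 1 to compound 3 (0.08 log units; within the scatter), a change within the scatter, though both of those compounds carry a pyridylmethyl group on the shared core, whereas compound 2 and compound 4 carry a benzyl group. Among the compounds with values here, no step joins the two groups of compounds, so the effect of the change in this setting is unknown. Since compound 2 gave no number, compound 4 is expected to remain weak, with 15000 nM estimated in a range from 4000 nM to 60000 nM.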

Compound 4, half-maximal inhibitory concentration: 66800 nM
Compound 4: the middle estimate sits 4.5-fold (0.65 log units) below what was measured, outside the stated range (above it).
By their numbers in this assay, from the lowest: compounds 3 and 1 (each within the scatter of the next); then compound 4.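

Going by these compounds alone, compound 2 is reported as "not active" without a number, so no step from it to compound 4 can be read. The compounds shown leave open what the amide-nitrogen change does when the shared core carries a benzyl group. No evidence at hand bears on this result.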